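Adding a Methylisoxazole to a Sulfonamide Nitrogen

The compounds below may be only part of what the source reports. "The series", "measured", "known", "first", "only" and "open" are said of these compounds alone.

Measured so far, in a functional assay on MCF7 cells (Homo sapiens) for cytotoxicity, read by sulforhodamine B assay, with a stated time of 72 h; on this read-out higher numbers stand for weaker inhibition and lower numbers for stronger inhibition:
Compound 1, `O=C1/C(=C/c2coc3ccccc3c2=O)N=C(c2ccc(Cl)cc2)N1c1ccc(S(=O)(=O)Nc2nccs2)cc1`, gives > 100000 nM, which is a limit of the assay rather than a number.
Compound 2, `CCOC1Oc2ccccc2C(=O)/C1=C/Nc1ccc(S(N)(=O)=O)cc1`, gives 22200 nM.

Compound 2 therefore carries the only real number shown, since for compound 1 the result sits at the limit of > 100000 nM in this assay, at which 1 of the 2 values shown sits. Compound 1 also has a different core, so its limit says nothing about how changes around the sulfonamide of compound 2 play out.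

Compound 3, `CCOC1Oc2ccccc2C(=O)/C1=C/Nc1ccc(S(=O)(=O)Nc2cc(C)on2)cc1`, is not yet measured. It differs from compound 2 in one place: 5-methyl-1,2-oxazol-3-yl in place of hydrogen on a sulfonamide nitrogen. The shared core of compound 2 and the chloro-free aryl attached to it stay the same; only the sulfamoyl becomes (5-methyl-1,2-oxazol-3-yl)sulfamoyl.

Going by the values given here, no measured pair shows what such a change does in this assay, so the step is expected to be small, in either direction, or none beyond the scatter. Compound 3 is accordingly expected at 30000 nM, within 8000 nM to 100000 nM, which means a step of a 1.4-fold higher number from compound 2 to compound 3 (0.13 log units; within the scatter).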

Compound 3, half-maximal inhibitory concentration: 25800 nM
Compound 3: middle estimate off by 1.2-fold (0.07 log units), on the high side; the range from low to high includes it.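

Going by these compounds alone, the pair of compound 2 and compound 3 is the first comparison here that differs in one place, and in this assay it shows a 1.2-fold higher number from compound 2 to compound 3 (0.07 log units; within the scatter) when 5-methyl-1,2-oxazol-3-yl takes the place of hydrogen on a sulfonamide nitrogen. So this nitrogen can carry a whole five-membered aromatic ring, rather than a lone hydrogen, with no change in the cell read-out beyond the usual scatter of repeated measurements, something neither earlier compound could show alone. Nothing measured here accounts for this absence of a change.

Going by these compounds, what remains open is whether this holds only for this ring or for the position in general, as a small methyl, an acetyl group or a six-membered pyridine ring on the same nitrogen could behave differently. Also open, on these data alone, is whether any change at this nitrogen can move the read-out beyond the scatter on the shared core, while compound 1, with its different core, gives no guidance on that question.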